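This account rests on a few compounds, and the source may have more. Where it says the series, first, only, none or still open, it means among the compounds named here.

The measured compounds, with their values:
compound 1, `CCCc1cc(N)c2cc(NC(=O)/C=C/c3ccc(Cl)cc3)ccc2n1`: 96 nM
compound 2, `CCCc1cc(N2CCCC2)c2cc(NC(=O)/C=C/c3ccc(C(F)(F)F)cc3)ccc2n1`: 2800 nM
compound 3, `CC(C)(C)c1cc(N)c2cc(NC(=O)/C=C/c3ccc(C(F)(F)F)cc3)ccc2n1`: 29 nM

In a functional assay on HEK293 cells for activation of melanin-concentrating hormone receptor 1 (Homo sapiens), read by inositol phosphate accumulation (on this read-out higher numbers stand for an effect only at larger amounts of compound and lower numbers for an effect already at smaller amounts), compound 1 gives 96 nM, the second highest of the three numbers. Compound 3 gives 29 nM, a lower number that lies beyond the usual scatter, while compound 2 gives 2800 nM, a far higher number. All three share one core and differ in their side groups.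

Compound 4 `CCCc1cc(N)c2cc(NC(=O)/C=C/c3ccc(SC)cc3)ccc2n1` has not yet been measured. It differs from compound 1 in a single place: methylsulfanyl in place of chloro on an aromatic carbon. Among the compounds with values here, no measured pair shows what this change does here. The step from compound 1 to compound 4 is expected to be small, within the scatter or a slight rise in the number: a 1.4-fold higher number from compound 1 to compound 4 (0.13 log units; within the scatter). For compound 4 the expected value is 130 nM, with a likely range from 45 nM to 400 nM.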

Compound 4, half-maximal effective concentration: 71 nM
For compound 4 the middle estimate is 1.8-fold (0.26 log units) above the measured one, and the stated range covers the measured number.
By their numbers in this assay, from the lowest: compound 3; then compounds 4 and 1 (each within the scatter of the next); then compound 2.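

In this assay, within the data shown here, methylsulfanyl in place of chloro gives a 1.4-fold lower number from compound 1 to compound 4 (0.13 log units; within the scatter), the first comparison here of two compounds that differ in one place. On this aromatic carbon, para to a large group, a chloro can thus give way to methylsulfanyl, which brings one more heavy atom and a hydrogen-bond acceptor, with no change beyond the scatter. Nothing measured here explains why the two groups read alike. As far as these compounds go, whether an amine, a carboxylic acid or a longer chain on this carbon would also leave the number in place remains open. So does what a group other than chloro or methylsulfanyl would do on the core of compound 1.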